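Adding (dimethylamino)methyl to compound 3

This account rests on a few compounds, and the source may have more. Where it says the series, first, only, none or still open, it means among the compounds named here.

Measured in a functional assay on MOLT-4 cells (Homo sapiens); a lower number here means a stronger inhibitor, a higher number a weaker inhibitor:
- compound 1 `Cc1ccc(/C=C/C(=O)Oc2ccc(/C=C3\CCCC(CN(C)C)C3=O)cc2)cc1` gives 3390 nM
- compound 2 `CN(C)CC1CCC/C(=C\c2ccc(OC(=O)/C=C/c3ccc(F)cc3)cc2)C1=O` gives 3780 nM
- compound 3 `COc1ccc(C(=O)Oc2ccc(/C=C3\CCCCC3=O)cc2)cc1` gives 34000 nM

At 34000 nM compound 3 has the highest number of the three. Compound 4 `COc1ccc(C(=O)Oc2ccc(/C=C3\CCCC(CN(C)C)C3=O)cc2)cc1` has (dimethylamino)methyl in place of hydrogen on a saturated ring carbon. Among the compounds with values here, the one measured step of a 1.1-fold higher number from compound 1 to compound 2 (0.05 log units; within the scatter) lies within the scatter and concerns another change, so it does not bear on this one. Compound 1 at 3390 nM and compound 2 at 3780 nM both carry this group but also differ from compound 3 elsewhere, so they are only indirect guidance. A large step to a lower number is therefore expected in this assay, estimated as a 6.8-fold lower number from compound 3 to compound 4 (0.83 log units; beyond the scatter) with no direct measurement behind it. The estimate for compound 4 is 5000 nM (expected range 1500 nM to 15000 nM).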

Compound 4, half-maximal inhibitory concentration: 2360 nM
Beside the measured number, compound 4's estimate is 2.1-fold (0.33 log units) above it; measured number inside the range.
By their numbers in this assay, from the lowest: compounds 4, 1 and 2 (each within the scatter of the next); then compound 3.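

In this assay the (dimethylamino)methyl group on a saturated ring carbon now has a direct reading, a 14-fold lower number from compound 3 to compound 4 (1.16 log units; beyond the scatter), a large step from this one change. With the group present, 4-methoxyphenyl on the carbonyl carbon reads within the scatter of either ethenyl group: a 1.6-fold lower number from compound 2 to compound 4 (0.20 log units; within the scatter) and a 1.4-fold lower number from compound 1 to compound 4 (0.16 log units; within the scatter). No evidence available here explains the step.

As far as these compounds go, whether a plain methyl, a morpholine or a longer chain such as (dimethylamino)ethyl on the same ring carbon would give a step of similar size remains open. So does the effect of this group on other esters of the series.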